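A few compounds are considered here, and "the series" means these few. Any claim that something is new, unique, unknown or untested is made for them only; others in the source may bear on it.

Working notes on the series. Going by the values given here, compound 1 `C[C@H](Nc1n[s+]([O-])nc1Nc1cccc(C(=O)N(C)C)c1O)C(C)(C)C` shows the higher of the two numbers so far in an assay on isolated protein for binding affinity to C-X-C chemokine receptor type 1 (Homo sapiens) (on this read-out lower numbers stand for stronger inhibition and higher numbers for weaker inhibition), where compound 1 gives 484 nM. Compound 2 `Cc1cc([C@H](Nc2n[s+]([O-])nc2Nc2cccc(C(=O)N(C)C)c2O)C(C)C)oc1C` gives 50 nM in this assay, a gap beyond the usual scatter. The unmeasured compound 3 `CN(C)C(=O)c1cccc(Nc2n[s+]([O-])nc2N[C@@H](c2ccco2)C2(C)CC2)c1O` comes from compound 1 by one change: (furan-2-yl)(1-methylcyclopropyl)methyl in place of 1,2,2-trimethylpropyl on a nitrogen on an aromatic ring. Among the compounds with values here, no step of this kind has been measured, so the expectation rests on what compound 1 and compound 2 show: an aromatic five-membered ring with one oxygen on the same nitrogen goes with a lower number in compound 2. The step from compound 1 to compound 3 is expected to be downward and beyond the scatter, near a 6.1-fold lower number from compound 1 to compound 3 (0.78 log units; beyond the scatter), because compound 2 gives 50 nM. For compound 3 the estimate in this assay is 80 nM, with a range from 25 nM to 250 nM.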

Compound 3, inhibition constant: 375 nM
Estimate against measurement, compound 3: 4.7-fold (0.67 log units) below, and the stated range ends below it.
By their numbers in this assay, from the lowest: compound 2; then compounds 3 and 1 (each within the scatter of the next).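

In this assay, (furan-2-yl)(1-methylcyclopropyl)methyl in place of 1,2,2-trimethylpropyl on a nitrogen on an aromatic ring gives a 1.3-fold lower number from compound 1 to compound 3 (0.11 log units; within the scatter), so this larger group with its two rings does not set compound 3 apart from compound 1. An aromatic five-membered ring with one oxygen at this position is therefore not enough on its own to reach the number of compound 2 (50 nM), whereas compound 3 gives 375 nM. No available measurement bears on what lies behind this result.

On these data alone, it remains open whether the gap between compound 2 and compound 3 follows from the groups on the furan ring or from the group sharing its carbon. As far as these compounds go, it is also open whether a phenyl or thiophene ring in place of the furan would give a number nearer that of compound 2.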